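Gem-dimethyl on the hydroxycyclohexylamine of compound 1

The compounds below may be only part of what the source reports. "The series", "measured", "known", "first", "only" and "open" are said of these compounds alone.

Among the measured compounds shown here, compound 1 `N#Cc1cnc(NCc2cnccc2C(F)(F)F)cc1N[C@H]1CC[C@@H](O)CC1` is the lower of the two numbers so far: in an assay on isolated protein for inhibition of protein kinase C theta type (Homo sapiens), read by TR-FRET, with a stated time of 2 h (a lower number here means a stronger inhibitor, a higher number a weaker inhibitor), compound 1 gives 100 nM. Compound 2 `COc1ncncc1CNc1cc(N[C@H]2CC[C@@H](O)CC2)c(C#N)cn1` carries a different aromatic amine and in this assay compound 2 gives 800 nM, a weaker reading than compound 1, which falls beyond the usual scatter.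

Compound 3 `CC1(C)C[C@H](Nc2cc(NCc3cnccc3C(F)(F)F)ncc2C#N)CC[C@H]1O` is not yet measured. It differs from compound 1 only in the saturated amine: 4-hydroxy-3,3-dimethylcyclohexyl in place of 4-hydroxycyclohexyl on a nitrogen on an aromatic ring. For the measured compounds named here, no measured pair in the set isolates this kind of change, so the direction rests on the parent alone.

The expected step from compound 1 to compound 3 in this assay is a 1.3-fold lower number from compound 1 to compound 3 (0.10 log units; within the scatter), that is, none beyond the scatter or a slight gain. For compound 3 the estimate in this assay is 80 nM, with a likely range from 25 nM to 300 nM.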

Compound 3, half-maximal inhibitory concentration: 100 nM
The estimate for compound 3 lay 1.3-fold (0.10 log units) below the measured number; the measured number falls inside the stated range.
By their numbers in this assay, from the lowest: compounds 1 and 3 (each within the scatter of the next); then compound 2.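

In this assay, placing 4-hydroxy-3,3-dimethylcyclohexyl in place of 4-hydroxycyclohexyl on a nitrogen on an aromatic ring gives no change at the digits printed from compound 1 to compound 3 (within the scatter). Among the compounds shown here, this is the first step that isolates a single place, and it shows that the saturated amine can carry the larger 4-hydroxy-3,3-dimethylcyclohexyl group with no reading beyond the scatter. Nothing available bears on why the two readings agree.

The compounds shown leave open whether an amine or a methoxy group in place of the hydroxyl, or a single methyl on the cyclohexyl ring, would read alike at this position. They also leave open whether the 4-hydroxy-3,3-dimethylcyclohexyl group would give a similar result with the aromatic amine of compound 2, which stands at 800 nM.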